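The source may hold more compounds than are shown below. What is called first, only, known or untested is meant among the compounds shown, and "the series" means these compounds.

Compound 2 `OC[C@H]1O[C@@H](n2cnc3c(SCc4cccc(Cl)c4)ncnc32)[C@H](O)[C@@H]1O` gives 18.2 nM in an assay on isolated protein for inhibition of Equilibrative nucleoside transporter 1 (Homo sapiens) (on this read-out higher numbers stand for weaker inhibition and lower numbers for stronger inhibition), the lower of the two numbers in hand; compound 1 `OC[C@H]1O[C@@H](n2cnc3c(SCc4ccccc4Cl)ncnc32)[C@H](O)[C@@H]1O` gives 117 nM in this assay. Compound 3 `OC[C@H]1O[C@@H](n2cnc3c(SCc4ccccc4Br)ncnc32)[C@H](O)[C@@H]1O` differs from compound 2 by 2-bromophenyl in place of 3-chlorophenyl on a saturated chain carbon bound to a sulfur. Among the compounds with values here, the only measured step that bears on this is a 6.4-fold lower number from compound 1 to compound 2 (0.81 log units; beyond the scatter), which moved the halogen from the 2-chlorophenyl of compound 1 to the 3-chlorophenyl of compound 2 and lowered the number by a modest amount beyond the scatter. Within the data shown here, compound 3 takes the halogen back to the arrangement of compound 1, so most of that gain is expected to be lost; chlorine against bromine has no precedent and is treated as neutral. Compound 3 is therefore estimated at 85 nM, with a range of 30 nM to 250 nM, an expected step of a 4.7-fold higher number from compound 2 to compound 3 (0.67 log units; beyond the scatter) in this assay.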

Compound 3, inhibition constant: 151 nM
Compound 3: the middle estimate sits 1.8-fold (0.25 log units) below what was measured; the measured number falls inside the stated range.
By their numbers in this assay, from the lowest: compound 2; then compounds 1 and 3 (each within the scatter of the next).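

In this assay, bromo in place of chloro on an aromatic carbon gives a 1.3-fold higher number from compound 1 to compound 3 (0.11 log units; within the scatter), so the identity of this halogen does not separate the 2-chlorophenyl and 2-bromophenyl compounds. Against the 3-chlorophenyl of compound 2, the 2-bromophenyl gives an 8.3-fold higher number from compound 2 to compound 3 (0.92 log units; beyond the scatter), so a second 2-halophenyl compound now stands on the weaker side of compound 2, and among these three compounds none goes against that pattern. No measurement in hand accounts for either step.

Open, from the compounds shown here alone, is whether a 3-bromophenyl would stay close to compound 2, which would show if the 3-chlorophenyl result carries over to another halogen. Also open, going by these compounds, is whether a halogen is needed at all, a question that plain phenyl or 3-methoxyphenyl on the same saturated chain carbon would address.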